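A few compounds are considered here, and "the series" means these few. Any claim that something is new, unique, unknown or untested is made for them only; others in the source may bear on it.

Three compounds sharing one core have numbers in an ADME assay on BEAS-2B cells (Homo sapiens) for cytotoxicity, read by fluorescence, with a stated time of 48 h; a higher number here means that more compound is tolerated, a lower number that less compound is tolerated. Compound 1 `Cc1ccoc1C(=O)N1CCCn2nc(C(=O)NCc3ccccc3)cc2C1`, with benzyl on the amide-type nitrogen, gives 50000 nM. Compound 2 `Cc1cccc(NC(=O)c2cc3n(n2)CCCN(C(=O)c2occc2C)C3)c1`, with 3-methylphenyl there, gives 3300 nM. Compound 3 `Cc1ccoc1C(=O)N1CCCn2nc(C(=O)Nc3cccc(F)c3)cc2C1`, with 3-fluorophenyl, gives 30000 nM. That places compound 3 level with compound 1, since a 1.7-fold lower number from compound 1 to compound 3 (0.22 log units; within the scatter) stays within the scatter, while a 9.1-fold higher number from compound 2 to compound 3 (0.96 log units; beyond the scatter) is a modest step beyond it. The largest step, a 15-fold lower number from compound 1 to compound 2 (1.18 log units; beyond the scatter), also involves compound 2.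

Compound 4 `Cc1ccoc1C(=O)N1CCCn2nc(C(=O)Nc3ccc(F)cc3)cc2C1` differs from compound 3 in one place: 4-fluorophenyl in place of 3-fluorophenyl on an amide-type nitrogen. In words, 4-fluorophenyl stands in place of 3-fluorophenyl on an amide-type nitrogen. For the measured compounds named here, no measured step makes this kind of swap, so the evidence is indirect. The steps beyond the scatter both involve the methyl-bearing compound 2. Compound 2 gives 3300 nM, and compound 4 carries fluoro, as compound 3 does. No direction can be favoured, so the expected change is a 1.1-fold lower number from compound 3 to compound 4 (0.05 log units; within the scatter), which would lie within the scatter. Compound 4 is estimated at 27000 nM, with an expected range of 10000 nM to 50000 nM.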

Compound 4, half-maximal cytotoxic concentration: 90000 nM
For compound 4 the middle estimate is 3.3-fold (0.52 log units) below the measured one; measured number above the stated range.
By their numbers in this assay, from the lowest: compound 2; then compounds 3, 1 and 4 (each within the scatter of the next, the first and the last beyond it).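

Moving the fluoro alone, with the same atoms joined differently, gives a 3.0-fold higher number from compound 3 to compound 4 (0.48 log units; beyond the scatter) in this assay and shows that this position responds to where a substituent stands on the phenyl ring, not only to which group is attached to the amide-type nitrogen. Swapping 3-methylphenyl for 4-fluorophenyl gives a large step, a 27-fold higher number from compound 2 to compound 4 (1.44 log units; beyond the scatter) while swapping benzyl for 4-fluorophenyl gives a 1.8-fold higher number from compound 1 to compound 4 (0.26 log units; within the scatter) and stays within the scatter, so those last two groups cannot be ranked against each other. Nothing measured here says why the place of the fluoro matters in this way.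

On these data alone, whether methyl follows the same trend as fluoro remains open, and 4-methylphenyl, compared with 3-methylphenyl, would test that directly. As far as these compounds go, it is also open how 2-fluorophenyl would compare, and whether a phenyl ring carrying an amine or a carboxylic acid would be tolerated differently.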